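This account rests on a few compounds, and the source may have more. Where it says the series, first, only, none or still open, it means among the compounds named here.

Measured so far in a functional assay on A549 cells (Homo sapiens) for inhibition, with a stated time of 48 h; a lower number here means a stronger inhibitor, a higher number a weaker inhibitor:
compound 1 `C[S+]([O-])/C=C/c1cc(=O)c2ccccc2o1` gives 10000 nM
compound 2 `COc1ccc2c(=O)cc(/C=C/[S+](C)[O-])oc2c1` gives 10500 nM
compound 3 `COc1ccc2c(=O)cc(/C=C/[S+](C)[O-])oc2c1O` gives > 10000 nM, a limit of the assay rather than a number.

Compound 1 has the lowest of the two numbers, and compound 2 sits within the scatter of it. Compound 3 gives only a limit. Compound 4 `COc1ccc2oc(/C=C/[S+](C)[O-])cc(=O)c2c1` is not yet measured; it differs from compound 1 by methoxy in place of hydrogen on an aromatic carbon. Among the compounds with values here, the one measured step of the same kind is a 1.1-fold higher number from compound 1 to compound 2 (0.02 log units; within the scatter), a methoxy in place of hydrogen on an aromatic carbon that left the number unchanged within the scatter. The step from compound 2 to compound 3 is unreadable because of the limit of > 10000 nM in this assay, at which 1 of the 3 values shown sits. For compound 4 no step beyond the scatter is therefore expected, a 1.1-fold higher number from compound 1 to compound 4 (0.02 log units; within the scatter). Compound 4 is estimated at 10500 nM, between 5000 nM and 22000 nM.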

Compound 4, half-maximal inhibitory concentration: 9000 nM
For compound 4 the middle estimate is 1.2-fold (0.07 log units) above the measured one; the range from low to high includes it.
By their numbers in this assay, from the lowest: compounds 4, 1 and 2 (each within the scatter of the next).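

In this assay, methoxy in place of hydrogen on this aromatic carbon gives a 1.1-fold lower number from compound 1 to compound 4 (0.05 log units; within the scatter). Compound 2 carries its methoxy on a different aromatic carbon of the same ring, and its step from compound 1 also lies within the scatter. Two placings of methoxy on this ring therefore leave the number unchanged within the scatter.

Compound 3 gives only a limit, so its step from compound 2 cannot be read: the limit of > 10000 nM in this assay, at which 1 of the 4 values shown sits. On these data alone, whether an amine, a carboxylic acid or a longer chain such as butoxy on this aromatic carbon would move the number beyond the scatter remains open.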